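A few compounds are considered here, and "the series" means these few. Any claim that something is new, unique, unknown or untested is made for them only; others in the source may bear on it.

Working notes on the amide series

Two members of this series have been measured in an assay for binding affinity to 5-hydroxytryptamine receptor 1F (Homo sapiens), read by radioligand binding; a lower number here means a stronger inhibitor, a higher number a weaker inhibitor. Compound 1, `Cc1cccc(C(=O)Nc2ccc3[nH]cc(C4CCN(C)CC4)c3n2)c1`, gives 5.8 nM in this assay. Going by the values given here, compound 2, `CN1CCC(c2c[nH]c3ccc(NC(=O)c4ccc([N+](=O)[O-])cc4)nc23)CC1`, gives 7.7 nM in this assay, and the one measured step, a 1.3-fold higher number from compound 1 to compound 2 (0.12 log units; within the scatter), is the only guide to how the group on the carbonyl carbon matters. On the two numbers shown, compound 2 holds the higher one, and its gap to compound 1 lies within the scatter, so the two are not ordered.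

The next compound, compound 3, is `CN1CCC(c2c[nH]c3ccc(NC(=O)C(C)(C)C)nc23)CC1`. The change from compound 2 is tert-butyl in place of 4-nitrophenyl on a carbonyl carbon; the rest of the shared core, with the amide-type nitrogen on the carbonyl carbon, is kept.

Among the compounds with values here, the only measured step that bears on this position, from compound 1 to compound 2, stayed within the scatter, yet it exchanged one six-membered aromatic ring for another. Within the data shown here, no measured step exchanges a ring for an open chain, so the present change is not covered by precedent. The expected step in this assay is therefore set as a 2.6-fold higher number from compound 2 to compound 3 (0.41 log units; beyond the scatter), a modest rise in the number, with a wide range. Compound 3 is estimated at 20 nM, with a range from 5 nM to 90 nM.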

Compound 3, inhibition constant: 62 nM
Beside the measured number, compound 3's estimate is 3.1-fold (0.49 log units) below it; the measured number falls inside the stated range.
By their numbers in this assay, from the lowest: compounds 1 and 2 (each within the scatter of the next); then compound 3.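

Working from the measured steps in this assay, the group on the carbonyl carbon now shows a clear effect on the number: the change to tert-butyl gives an 8.1-fold higher number from compound 2 to compound 3 (0.91 log units; beyond the scatter), and the comparison with the other aromatic amide gives an 11-fold higher number from compound 1 to compound 3 (1.03 log units; beyond the scatter). The earlier exchange of 3-methylphenyl for 4-nitrophenyl stayed within the scatter, so among these three compounds the two six-membered aromatic rings stand together, and tert-butyl, with no ring and fewer heavy atoms, stands apart. The measurements shown offer no explanation for this separation.

The step removes the ring and reduces the group's size at once, so the compounds shown cannot tell which of these changes goes with the higher number; a cyclohexyl ring or a longer open chain such as n-pentyl on the carbonyl carbon would help separate them. Going by these compounds, it also remains open how widely the tolerance seen with 3-methylphenyl and 4-nitrophenyl extends to other aromatic rings, such as a pyridine ring or a phenyl ring carrying an amine or a carboxylic acid.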